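Two weakening changes meet in one thiazole compound

The compounds below may be only part of what the source reports. "The series", "measured", "known", "first", "only" and "open" are said of these compounds alone.

The series rests on a shared core carrying a trimethoxyphenyl group and a second aryl group on a thiazole, with an amino substituent that is varied. Compound 1 `CNc1nc(-c2cc(OC)c(OC)c(OC)c2)c(-c2ccc(C)cc2)s1` is the reference point: in a functional assay on Jurkat cells (Homo sapiens) for antiproliferative activity, read by MTT assay, with a stated time of 72 h (a lower number here means a stronger inhibitor, a higher number a weaker inhibitor), compound 1 gives 19 nM. Compound 2 `CNc1nc(-c2cc(OC)c(OC)c(OC)c2)c(-c2ccc(C(F)(F)F)cc2)s1` differs from it by trifluoromethyl in place of methyl on an aromatic carbon, and in this assay compound 2 gives 3010 nM, a step of a 160-fold higher number from compound 1 to compound 2 (2.20 log units; beyond the scatter). Compound 3 `COc1cc(-c2nc(N(C)C)sc2-c2ccc(C)cc2)cc(OC)c1OC` differs from compound 1 by methyl in place of hydrogen on a nitrogen on an aromatic ring; in this assay compound 3 gives 6660 nM, the step being a 350-fold higher number from compound 1 to compound 3 (2.54 log units; beyond the scatter), and it stands highest of the three measured numbers.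

Compound 4 `COc1cc(-c2nc(N(C)C)sc2-c2ccc(C(F)(F)F)cc2)cc(OC)c1OC` has not been measured. It differs from compound 3 by trifluoromethyl in place of methyl on an aromatic carbon, the same kind of change as that from compound 1 to compound 2, made here on the core of compound 3 rather than on the core of compound 1; the two places are described in the same words. Among the compounds with values here, the expectation is that compound 4 will weaken further, with a step of about a 7.5-fold higher number from compound 3 to compound 4 (0.88 log units; beyond the scatter), because the earlier step of a 160-fold higher number from compound 1 to compound 2 (2.20 log units; beyond the scatter) was large, though the starting number of compound 3 is already high and the assay may not resolve a number so far out. Compound 4 is therefore estimated at 50000 nM, expected to lie between 12000 nM and 250000 nM, with a real chance that only a limit is reported.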

Compound 4, half-maximal inhibitory concentration: > 10000 nM
Compound 4: only a limit was reported; the forecaster's own chance of this, stated with the estimate: 45%; the middle value is on the limit's open side.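

In this assay compound 4 gives only a limit of the assay, > 10000 nM, and not a number. Carried to the second core, trifluoromethyl in place of methyl gives an at least 1.5-fold higher number from compound 3 to compound 4 (0.17 log units; that floor lies within the scatter), a floor that does not by itself show any weakening beyond the scatter, and it neither confirms nor rules out the large step seen on the first core: the same change on two cores in this assay, a 160-fold higher number (2.20 log units; beyond the scatter) from compound 1 to compound 2 and an at least 1.5-fold higher number (0.17 log units; that floor lies within the scatter) from compound 3 to compound 4; the limit leaves it open whether they differ. Read the other way, methyl in place of hydrogen on the nitrogen gives an at least 3.3-fold higher number from compound 2 to compound 4 (0.52 log units; beyond the scatter), so this change weakens on both cores, but how closely the sizes agree stays unknown: the same change on two cores in this assay, a 350-fold higher number (2.54 log units; beyond the scatter) from compound 1 to compound 3 and an at least 3.3-fold higher number (0.52 log units; beyond the scatter) from compound 2 to compound 4; the limit leaves it open whether they differ.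

The compounds shown leave open how far past its limit compound 4 really lies, and with it whether the two weakening changes add up in full or overlap. They also leave open how the shared core would respond to an ethyl group or a longer chain on the nitrogen, or to a chlorine or a methoxy group in place of the methyl on the aromatic ring.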